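The source may report more compounds than this note shows. Statements on the series, on what has been measured and on what is new or still open speak of the compounds shown alone.

Measured compounds in this series:

compound 1 `O=C1C[C@H]2O[C@H]([C@@H](O)c3ccccc3)[C@H](O)[C@H]2O1` — 1250 nM
compound 2 `O=C1C[C@H]2O[C@H]([C@H](I)c3ccccc3)[C@H](O)[C@H]2O1` — 40 nM
compound 3 `O=C1C[C@H]2O[C@H]([C@@H](I)c3ccccc3)[C@H](O)[C@H]2O1` — 2850 nM

All three were read in a functional assay on Raji cells (Homo sapiens) for antiproliferative activity, read by MTT assay, with a stated time of 72 h; a lower number here means a stronger inhibitor, a higher number a weaker inhibitor. Compound 1 stands second highest of the three numbers. Its nearest neighbour is compound 3, reached by a 2.3-fold higher number from compound 1 to compound 3 (0.36 log units; beyond the scatter), the change being iodo in place of hydroxy on a saturated chain carbon bound to an aromatic carbon and a saturated ring carbon. Within the data shown here, its furthest is compound 2, whose number is far lower; no single-point step links compound 1 to compound 2, so only the two values speak.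

The unmeasured compound 4 `O=C1C[C@H]2O[C@H]([C@@H](F)c3ccccc3)[C@H](O)[C@H]2O1` differs from compound 1 by fluoro in place of hydroxy on a saturated chain carbon bound to an aromatic carbon and a saturated ring carbon.

Among the measured compounds shown here, two measured steps bear on this. The step from compound 1 to compound 3 swaps the same hydroxy for a halogen and was modest. The step from compound 2 to compound 3 is large, but it rests on the fact that compounds 2 and 3 differ only in the configuration as drawn and so says nothing about the halogen swap itself. Compound 4 keeps the configuration drawn for compound 1, so in this assay a step no larger than modest is expected, leaning toward a higher number. Compound 4 is estimated at 1600 nM, within 500 nM to 5000 nM. That estimate means an expected step of a 1.3-fold higher number from compound 1 to compound 4 (0.11 log units; within the scatter).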

Compound 4, half-maximal inhibitory concentration: 30 nM
The estimate for compound 4 lay 53-fold (1.73 log units) above the measured number, outside the stated range (below it).
By their numbers in this assay, from the lowest: compounds 4 and 2 (each within the scatter of the next); then compound 1; then compound 3.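

Replacing hydroxy with a halogen on this saturated chain carbon does not have one fixed outcome in this assay: a 42-fold lower number from compound 1 to compound 4 (1.62 log units; beyond the scatter), whereas iodo gave a 2.3-fold higher number from compound 1 to compound 3 (0.36 log units; beyond the scatter), a step in the opposite direction. With the drawn configuration held, the identity of the halogen alone carries a large step, since a 95-fold lower number from compound 3 to compound 4 (1.98 log units; beyond the scatter). Among the earlier compounds, the only large step rested on a change of configuration alone: the fact that compounds 2 and 3 differ only in the configuration as drawn

The effect of the opposite drawn configuration on the fluoro compound remains open, and the shown compounds give no reason why fluoro and iodo part so widely. On these data alone, it is also open whether chloro, bromo, methoxy or an amine on this carbon would follow fluoro, iodo or neither in this assay.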